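Replacing Benzyl with Phenethylcarbonyl on the Ring Nitrogen

The source may report more compounds than this note shows. Statements on the series, on what has been measured and on what is new or still open speak of the compounds shown alone.

Of the compounds shown here, three sharing one core have been measured in a functional assay on cells (T-cell, Homo sapiens) for inhibition; on this read-out lower numbers stand for stronger inhibition and higher numbers for weaker inhibition. Compound 1 `COc1ccc(-c2cnc3nc(N)nc(N4CCN(C(=O)Nc5ccc(C)cc5)CC4)c3n2)cc1OC` gives 0.8 nM. Compound 2 `COc1ccc(-c2cnc3nc(N)nc(N4CCN(C(=O)Nc5ccc(C#N)cc5)CC4)c3n2)cc1OC` gives 74 nM. Compound 3 `COc1ccc(-c2cnc3nc(N)nc(N4CCN(Cc5ccccc5)CC4)c3n2)cc1OC` gives 900 nM, the highest number of the three and thus the weakest inhibitor; the steps of a 1100-fold higher number from compound 1 to compound 3 (3.05 log units; beyond the scatter) and a 12-fold higher number from compound 2 to compound 3 (1.09 log units; beyond the scatter) are both large and well beyond the scatter.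

Compound 4 `COc1ccc(-c2cnc3nc(N)nc(N4CCN(C(=O)CCc5ccccc5)CC4)c3n2)cc1OC` has not yet been measured. It differs from compound 3 in one place: phenethylcarbonyl in place of benzyl on an amine nitrogen in a ring. The two measured steps that end at compound 3 both exchanged a carbamoyl group, which carries a carbonyl, for benzyl, and both raised the number strongly. Compound 4 brings a carbonyl back onto the same ring nitrogen, though as a phenethylcarbonyl rather than a carbamoyl, so a downward step beyond the scatter is expected, smaller than the steps seen from the carbamoyl compounds because of a 12-fold higher number from compound 2 to compound 3 (1.09 log units; beyond the scatter) as the nearer comparison. The expected step is a 6.0-fold lower number from compound 3 to compound 4 (0.78 log units; beyond the scatter). Compound 4 is estimated at 150 nM, within a range from 30 nM to 600 nM.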

Compound 4, half-maximal inhibitory concentration: 100 nM
For compound 4 the middle estimate is 1.5-fold (0.18 log units) above the measured one, and the stated range covers the measured number.
By their numbers in this assay, from the lowest: compound 1; then compounds 2 and 4 (each within the scatter of the next); then compound 3.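

In this assay, the ring nitrogen does not need a carbamoyl group for the number to fall below that of the benzyl compound, since phenethylcarbonyl gives a 9.0-fold lower number from compound 3 to compound 4 (0.95 log units; beyond the scatter) on its own. Set against the (4-cyanophenyl)carbamoyl group, it gives a 1.4-fold higher number from compound 2 to compound 4 (0.13 log units; within the scatter) and so cannot be told apart from that group here. Set against the (4-methylphenyl)carbamoyl group, it gives a 130-fold higher number from compound 1 to compound 4 (2.10 log units; beyond the scatter) and therefore does not reach the very low number of compound 1.

Still open, on these data alone, is whether the carbonyl or the longer chain carries the step from benzyl, a question that a benzoyl or a phenethyl group on the same ring nitrogen would address. Nothing available here explains why these groups differ.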